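This account rests on a few compounds, and the source may have more. Where it says the series, first, only, none or still open, it means among the compounds named here.

Measured so far in a functional assay on MCF7 cells (Homo sapiens) for cytotoxicity, read by MTT assay, with a stated time of 72 h; on this read-out lower numbers stand for stronger inhibition and higher numbers for weaker inhibition:
- compound 1 `COc1cc(/C=C/C(=O)Nc2cc3c(Nc4ccc(F)c(Cl)c4)ncnc3cc2O[C@H]2CCOC2)cc(OC)c1OC`: 28400 nM
- compound 2 `COc1cc(/C=C/C(=O)Nc2cc3c(Nc4ccc(F)c(Cl)c4)ncnc3cc2O[C@H]2CCOC2)cc(OC)c1`: 30300 nM

Compound 2, at 30300 nM, lies within the scatter of compound 1, so the two cannot be ranked. The next compound is compound 3 `COc1cc(/C=C/C(=O)Nc2cc3c(Nc4ccc(F)c(Cl)c4)ncnc3cc2O[C@H]2CCOC2)cc(OC)c1O`, with the change (hydroxy in place of hydrogen on an aromatic carbon), which is hydroxy in place of hydrogen on an aromatic carbon. Among the measured compounds shown here, one measured step bears on this carbon: a 1.1-fold higher number from compound 1 to compound 2 (0.03 log units; within the scatter). That step swapped methoxy for hydrogen at the same place and stayed within the scatter. For the measured compounds named here, no measured compound carries hydroxy there, so this single step is the only guide, and a small effect is expected in this assay, with no direction favoured. The expected step is a 1.1-fold lower number from compound 2 to compound 3 (0.05 log units; within the scatter), which would be none beyond the scatter. For compound 3 the estimated value is 27000 nM, with an expected range from 13000 nM to 55000 nM.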

Compound 3, half-maximal inhibitory concentration: 30500 nM
For compound 3 the middle estimate is 1.1-fold (0.05 log units) below the measured one; the range from low to high includes it.
By their numbers in this assay, from the lowest: compounds 1, 2 and 3 (each within the scatter of the next).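

In this assay, hydroxy in place of hydrogen on the 3,5-dimethoxyphenyl gives a 1.0-fold higher number from compound 2 to compound 3 (0.00 log units; within the scatter) and stays within the scatter, and hydrogen in place of methyl on that same oxygen gives a 1.1-fold higher number from compound 1 to compound 3 (0.03 log units; within the scatter) and also stays within the scatter. This position, para to a large group, now carries hydrogen, methoxy and hydroxy, and the three compounds cannot be told apart, so the hydroxy adds a hydrogen-bond donor here with no readable shift in this read-out. No supporting measurement on the origin of this flat result is at hand.

From the compounds shown here alone, whether an amine, a carboxylic acid or a longer alkoxy chain at this position would move the number beyond the scatter remains open. Also open, going by these compounds, is what happens when the two methoxy groups ortho to it are replaced by hydrogen.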